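This account rests on a few compounds, and the source may have more. Where it says the series, first, only, none or still open, it means among the compounds named here.

Of the compounds shown here, two have so far been measured in a functional assay on NCI-H1975 cells (Homo sapiens) for inhibition, read by MTT assay, with a stated time of 72 h; a higher number here means a weaker inhibitor, a lower number a stronger inhibitor. Compound 1 `O=C(CSc1nc(Nc2ccccc2)c2ccccc2n1)Nc1cccc(Br)c1` gives 10100 nM, and compound 2 `C=CC(=O)Nc1cccc(NC(=O)CSc2nc(Nc3ccccc3F)c3ccccc3n2)c1` gives 6580 nM. Compound 2 has the lowest number of the two, but its gap to compound 1 lies within the scatter, so the two cannot be told apart. Compound 3 `C=CC(=O)Nc1cccc(NC(=O)CSc2nc(Nc3ccc(Cl)cc3Cl)c3ccccc3n2)c1` is not yet measured; it differs from compound 2 by 2,4-dichlorophenyl in place of 2-fluorophenyl on a nitrogen on an aromatic ring. Within the data shown here, no measured pair isolates that change, so a small step of uncertain direction is expected, a 1.3-fold lower number from compound 2 to compound 3 (0.12 log units; within the scatter). In this assay compound 3 is expected to give 5000 nM, with a range from 1500 nM to 20000 nM.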

Compound 3, half-maximal inhibitory concentration: 5990 nM
Compound 3: middle estimate off by 1.2-fold (0.08 log units), on the low side; measured number inside the range.
By their numbers in this assay, from the lowest: compounds 3, 2 and 1 (each within the scatter of the next).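

Placing 2,4-dichlorophenyl where 2-fluorophenyl stood on this nitrogen gives a 1.1-fold lower number from compound 2 to compound 3 (0.04 log units; within the scatter) in this assay. Among these compounds, this is the first pair that isolates a change at this position, and the swap of one halogen-bearing phenyl for another leaves no readable shift in the number. Nothing measured here offers a reason for this result. Still open, on these data alone, is whether a phenyl carrying a methoxy group or an amine, or a cyclohexyl group with no aromatic ring, would move the number beyond the scatter at this nitrogen.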